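Swapping the ring-nitrogen substituent in a thiophene carboxamide series

The source may hold more compounds than are shown below. What is called first, only, known or untested is meant among the compounds shown, and "the series" means these compounds.

Measured compounds:
- compound 1 `NC(=O)c1c(NC(=O)c2ccccc2Cl)sc2c1CCN(Cc1c(Cl)cccc1Cl)C2`: 4740 nM
- compound 2 `NC(=O)c1c(NC(=O)c2cccc([N+](=O)[O-])c2)sc2c1CCN(Cc1c(Cl)cccc1Cl)C2`: 13500 nM

In a functional assay on MKN-74 cells (Homo sapiens) for antiproliferative activity, with a stated time of 24 h (on this read-out higher numbers stand for weaker inhibition and lower numbers for stronger inhibition), compound 1 gives 4740 nM, the lowest of the two numbers; compound 2 gives 13500 nM. Going by the values given here, the one measured step, a 2.8-fold higher number from compound 1 to compound 2 (0.45 log units; beyond the scatter), concerns the group on the carbonyl carbon, not the position changed here.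

Compound 3 `NC(=O)c1c(NC(=O)c2ccccc2Cl)sc2c1CCN(C(=S)Nc1ccccc1I)C2` differs from compound 1 at another place: a group of 10 heavy atoms (7 carbon, 1 nitrogen, 1 sulfur, 1 iodine; one six-membered aromatic ring of carbon only) in place of a group of 9 heavy atoms (7 carbon, 2 chlorine; one six-membered aromatic ring of carbon only), on an amine nitrogen in a ring. Among the compounds with values here, no measured step touches this ring nitrogen, so nothing in this assay shows how the substituent there matters. The expectation for compound 3 therefore rests on compound 1 alone, and the estimated step of a 1.1-fold higher number from compound 1 to compound 3 (0.02 log units; within the scatter) is none beyond the scatter, with a wide range to reflect that uncertainty. Compound 3 is estimated at 5000 nM, between 1500 nM and 16000 nM.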

Compound 3, half-maximal inhibitory concentration: 2630 nM
For compound 3 the middle estimate is 1.9-fold (0.28 log units) above the measured one, within the range that was stated.
By their numbers in this assay, from the lowest: compounds 3 and 1 (each within the scatter of the next); then compound 2.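

In this assay replacing the 2,6-dichlorobenzyl group on the ring nitrogen with a group that holds a double bond outside aromatic rings, a hydrogen-bond donor and a hydrogen-bond acceptor gives a 1.8-fold lower number from compound 1 to compound 3 (0.26 log units; within the scatter) and so no clear difference. Going by these compounds alone, this is the first sign that the ring nitrogen can carry two quite different groups with numbers in the same range, although a single pair cannot show how far that extends. Nothing available explains this result.

The compounds shown leave open how a small methyl group, a carboxylic acid or a longer chain on the ring nitrogen would fare. They also leave open whether the step from 2-chlorophenyl to 3-nitrophenyl on the carbonyl carbon would hold with the group of compound 3 in place.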